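Three limits and a pyridin-2-yl swap

This account rests on a few compounds, and the source may have more. Where it says the series, first, only, none or still open, it means among the compounds named here.

Compound 1 `Cc1ccccc1-c1cc(C(=O)N2CCC3(CC2)CC(=O)c2nn(C(C)(C)C)cc2O3)c2ccccc2n1` gives > 10000 nM as a limit
Compound 2 `CC(C)(C)n1cc2c(n1)C(=O)CC1(CCN(C(=O)c3cc(-c4ccc(F)cc4)nc4ccccc34)CC1)O2` gives > 10000 nM as a limit
Compound 3 `COc1ccc(-c2cc(C(=O)N3CCC4(CC3)CC(=O)c3nn(C(C)(C)C)cc3O4)c3ccccc3n2)cc1` gives > 10000 nM as a limit

In a functional assay on MDA-MB-231 cells (Homo sapiens) for inhibition, read by MTT assay, with a stated time of 72 h (a higher number here means a weaker inhibitor, a lower number a stronger inhibitor), compound 3 stands at > 10000 nM and this is a limit, not a number. All the data share this ceiling, namely the limit of > 10000 nM in this assay, at which 3 of the 3 values shown sit, and nothing finer. Compound 4 `CC(C)(C)n1cc2c(n1)C(=O)CC1(CCN(C(=O)c3cc(-c4ccccn4)nc4ccccc34)CC1)O2` carries pyridin-2-yl in place of 4-methoxyphenyl on an aromatic carbon next to the ring nitrogen. For the measured compounds named here, the steps that bear on it are a step that the two limits leave unreadable from compound 1 to compound 2 and a step that the two limits leave unreadable from compound 1 to compound 3 and a step that the two limits leave unreadable from compound 2 to compound 3 and none has a readable size. No step beyond the scatter and no direction is therefore expected, the expected step being a step that the limit leaves unreadable from compound 3 to compound 4 in this assay by this estimate. Compound 4 is expected at 12000 nM with an estimated range of 4000 nM to 40000 nM and most likely only a limit.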

Compound 4, half-maximal inhibitory concentration: 8100 nM
The estimate for compound 4 lay 1.5-fold (0.17 log units) above the measured number, and the stated range covers the measured number.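

In this assay, for the compounds shown here, compound 4, with pyridin-2-yl at this position, gives 8100 nM, the only value shown that is a number and not a limit. The steps are an at least 1.2-fold lower number from compound 3 to compound 4 (0.09 log units; that floor lies within the scatter), an at least 1.2-fold lower number from compound 2 to compound 4 (0.09 log units; that floor lies within the scatter) and an at least 1.2-fold lower number from compound 1 to compound 4 (0.09 log units; that floor lies within the scatter), so each is only a floor, and none shows a change beyond the scatter. A ring with a nitrogen at this position thus gives a readable value, while the other compounds stay at the ceiling: the limit of > 10000 nM in this assay, at which 3 of the 4 values shown sit.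

As far as these compounds go, the steps among compound 1, compound 2 and compound 3 cannot be read, and the true size of the steps to compound 4 stays open. Also open, from the compounds shown here alone, is whether a phenyl ring carrying an amine or a carboxylic acid at this position would give a number clearly lower than that of compound 4.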